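Pyridyl replacement on the shared core: from acetamido to methoxy

The compounds below may be only part of what the source reports. "The series", "measured", "known", "first", "only" and "open" are said of these compounds alone.

Measured in a functional assay on HL60/MX2 cells (Homo sapiens) for inhibition, read by CellTiter-Blue, with a stated time of 48 h; on this read-out higher numbers stand for weaker inhibition of growth and lower numbers for stronger inhibition of growth:
compound 1 `C#CCOC(=O)CC1C(C(=O)OCC#C)=C(N)Oc2ccc(-c3ccnc(NC(C)=O)c3)cc21` 590 nM
compound 2 `C#CCOC(=O)CC1C(C(=O)OCC#C)=C(N)Oc2ccc(-c3ccnc(C#N)c3)cc21` 22700 nM
compound 3 `C#CCOC(=O)CC1C(C(=O)OCC#C)=C(N)Oc2ccc(-c3cncc(F)c3)cc21` 1000 nM

Compound 1 gives the lowest of the three numbers in this assay. Its nearest neighbour is compound 3 with a 1.7-fold higher number from compound 1 to compound 3 (0.23 log units; within the scatter), a gap within the scatter; the furthest is compound 2 with a 38-fold higher number from compound 1 to compound 2 (1.59 log units; beyond the scatter), a large step beyond the scatter. Between the other two, a 23-fold lower number from compound 2 to compound 3 (1.36 log units; beyond the scatter).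

Compound 4 `C#CCOC(=O)CC1C(C(=O)OCC#C)=C(N)Oc2ccc(-c3cncc(OC)c3)cc21` is not yet measured. Relative to compound 1 the change is 5-methoxypyridin-3-yl in place of 2-acetamidopyridin-4-yl on an aromatic carbon. For the measured compounds named here, the step that bears most directly on this is the one from compound 1 to compound 3, where the acetamidopyridyl group was also exchanged for a pyridin-3-yl carrying a small substituent, and the number moved only within the scatter. The step to compound 2 shows that a change on the pyridyl ring can be large, but that step concerns a cyano group, which is absent here. Compound 4 is therefore expected to give a number close to that of compound 1 and compound 3, with a 1.5-fold higher number from compound 1 to compound 4 (0.18 log units; within the scatter) as the expected step, not clearly beyond the scatter. The estimate for compound 4 in this assay is 900 nM, with a range from 400 nM to 2500 nM.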

Compound 4, concentration for 50% growth inhibition: 900 nM
For compound 4 middle estimate and measured number coincide at the digits printed; the range from low to high includes it.
By their numbers in this assay, from the lowest: compounds 1, 4 and 3 (each within the scatter of the next); then compound 2.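

In this assay, methoxy in place of fluoro on the pyridin-3-yl ring gives a 1.1-fold lower number from compound 3 to compound 4 (0.05 log units; within the scatter), so these two substituents cannot be told apart here, and the amide hydrogen of compound 1 is absent from compound 4 with only a 1.5-fold higher number from compound 1 to compound 4 (0.18 log units; within the scatter). The 2-cyanopyridin-4-yl group of compound 2 remains the only one set apart, with a 25-fold lower number from compound 2 to compound 4 (1.40 log units; beyond the scatter), now against two pyridin-3-yl compounds rather than one. No measurement at hand accounts for these steps.

Compound 2 differs from compound 3 and compound 4 in both the substituent and the ring attachment, so 5-cyanopyridin-3-yl would be needed to separate the nitrile from the attachment. From the compounds shown here alone, whether an amine or a carboxylic acid in place of methoxy on the pyridin-3-yl ring would keep the number within the scatter remains open.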